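A few compounds are considered here, and "the series" means these few. Any claim that something is new, unique, unknown or untested is made for them only; others in the source may bear on it.

Measured so far:
compound 1, `O=C1NC(c2ccccc2)CN1S(=O)(=O)c1ccc2c(c1)CCC2`, with 910 nM in a functional assay on A549 cells (Homo sapiens) for cytotoxicity; a higher number here means a weaker inhibitor, a lower number a stronger inhibitor;
compound 3, `O=C1NC(c2ccccc2)CN1S(=O)(=O)c1ccc(Cl)cc1`, with 9470 nM;
compound 2, `Cc1ccc(C2CN(S(=O)(=O)c3ccc(Cl)cc3)C(=O)N2)cc1`, with 158000 nM.

Compound 1 gives the lowest number of the three. The difference between the core of compound 1 and the core of compound 3 is not broken down here. Compound 3 and compound 2 differ in one place: methyl in place of hydrogen on an aromatic carbon. That change made a large step, a 17-fold higher number from compound 3 to compound 2 (1.22 log units; beyond the scatter).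

Compound 4, `Cc1ccc(C2CN(S(=O)(=O)c3ccc4c(c3)CCC4)C(=O)N2)cc1`, has not been measured. It differs from compound 1 in the same way: methyl in place of hydrogen on an aromatic carbon. The place of the change reads the same in both pairs, so this is the same change. Because the earlier change gave a 17-fold higher number from compound 3 to compound 2 (1.22 log units; beyond the scatter), a step of similar size is expected here, a 16-fold higher number from compound 1 to compound 4 (1.22 log units; beyond the scatter). Compound 4 is therefore estimated to give 15000 nM in this assay, most likely between 3000 nM and 60000 nM.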

Compound 4, half-maximal inhibitory concentration: 99200 nM
Compound 4: middle estimate off by 6.6-fold (0.82 log units), on the low side, and the stated range ends below it.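

In this assay, turning phenyl into 4-methylphenyl gave a higher number, meaning a weaker inhibitor, on both cores, this time a 110-fold higher number from compound 1 to compound 4 (2.04 log units; beyond the scatter). The direction of the change therefore carried over from one core to the other, but its size did not: the same change on two cores in this assay, a 17-fold higher number (1.22 log units; beyond the scatter) from compound 3 to compound 2 and a 110-fold higher number (2.04 log units; beyond the scatter) from compound 1 to compound 4, 6.5-fold (0.82 log units) apart, beyond the scatter of two such steps These two pairs show that the size of this step can differ with the core, but they do not show why it differs or how large it would be on a further core.

Only hydrogen and methyl appear at this position on the phenyl ring. The compounds shown leave open whether a larger alkyl group, a methoxy group or an amine there would also give a higher number.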